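Weak antiproliferative series: a heteroaryl swap at the chain carbon

The compounds below may be only part of what the source reports. "The series", "measured", "known", "first", "only" and "open" are said of these compounds alone.

Measured compounds:
compound 1 `O=C1O/C(=C\Cn2cnc3c(F)nc(F)c(Cl)c32)C(OCc2ccccc2)=C1OCc1ccccc1`: 55000 nM
compound 2 `O=C1O/C(=C\Cn2cnc3c(Cl)c(F)nc(F)c32)C(OCc2ccccc2)=C1OCc1ccccc1`: 50000 nM
compound 3 `O=C1NC(O)(CCn2cnc3cncc(Br)c32)C(OCc2ccccc2)=C1OCc1ccccc1`: > 100000 nM

Compound 1, compound 2 and compound 3 share a furanone-type core carrying two benzyloxy groups, each tested in a functional assay on SW-620 cells (Homo sapiens) for antiproliferative activity, read by MTT assay, with a stated time of 72 h; on this read-out higher numbers stand for weaker inhibition and lower numbers for stronger inhibition. Compound 2 gives 50000 nM in this assay. Compound 1 gives 55000 nM in this assay. For compound 3 this assay reports only a limit, > 100000 nM, not a number (the limit of > 100000 nM in this assay, at which 1 of the 3 values shown sits). Among the two numbers shown, compound 2 has the lowest, and its nearest neighbour is compound 1; the step of a 1.1-fold lower number from compound 1 to compound 2 (0.04 log units; within the scatter) is within the scatter.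

Compound 4 `O=C1O/C(=C\Cn2cnc3cc[nH]c3c2=O)C(OCc2ccccc2)=C1OCc1ccccc1` has not yet been measured in this assay. It differs from compound 2 in one place: a group of 10 heavy atoms (6 carbon, 3 nitrogen, 1 oxygen; one five-membered aromatic ring with 1 hetero atom, one six-membered aromatic ring with 2 hetero atoms) in place of a group of 12 heavy atoms (6 carbon, 3 nitrogen, 2 fluorine, 1 chlorine; one five-membered aromatic ring with 2 hetero atoms, one six-membered aromatic ring with 1 hetero atom), on a saturated chain carbon bound to a double-bonded chain carbon. For the measured compounds named here, the only measured step that bears on this change is the one between compound 1 and compound 2, which exchanges one halogenated heteroaryl group for another and stays within the scatter. Going by the values given here, the replacement in compound 4 is larger, bringing in a hydrogen-bond donor and removing the halogens, and no measured step covers such a change directly. Compound 4 is therefore expected to remain weak, with an estimated step of a 1.2-fold higher number from compound 2 to compound 4 (0.08 log units; within the scatter) from compound 2. For compound 4 the estimated value in this assay is 60000 nM, expected to fall between 20000 nM and 180000 nM.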

Compound 4, half-maximal inhibitory concentration: > 100000 nM
Compound 4 was reported as a limit; the forecaster's own chance of this, stated with the estimate: 35%; middle value at least 1.6-fold (0.22 log units) away from the limit.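

Where the earlier pair only exchanged one halogenated group for another, the new change, on the saturated chain carbon bound to a double-bonded chain carbon, removes the halogens and brings in a group with a hydrogen-bond donor, and in this assay it gives an at least 2.0-fold higher number from compound 2 to compound 4 (0.30 log units; that floor lies within the scatter) and also an at least 1.8-fold higher number from compound 1 to compound 4 (0.25 log units; that floor lies within the scatter). This larger exchange therefore brought no lower number, so neither the halogen-free group nor the donor it carries rescues the weak activity of these compounds, though both floors lie within the scatter and a real loss is not established. Compound 4 is reported only as a limit, not as a number, so the true size of both steps stays unknown: the limit of > 100000 nM in this assay, at which 2 of the 4 values shown sit.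

The compounds shown change the halogens and the donor together, so they leave open what each contributes alone, and a heteroaryl group with a single chlorine and no fluorine would begin to separate the two. They also leave open whether an amine or a carboxylic acid on that heteroaryl group, or a longer chain in place of the saturated chain carbon, would give a lower number in this assay.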